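Replacing phenyl with 4-chlorobenzyl: expectation for compound 4

The compounds below may be only part of what the source reports. "The series", "measured", "known", "first", "only" and "open" are said of these compounds alone.

Compound 3 `Cc1nc(-c2ccccc2)oc1-c1csc(-c2ccccc2)n1` was tested in an ADME assay on A549 cells (Homo sapiens) for inhibition, read by MTT assay; on this read-out lower numbers stand for stronger inhibition of growth and higher numbers for weaker inhibition of growth. In this assay compound 3 gives > 250 ug/mL, which is a limit of the assay rather than a number. Compound 1 `Cc1nc(-c2ccc(F)cc2)oc1-c1csc(Cc2ccc(F)cc2)n1` gives > 250 ug/mL in this assay, again a limit. Compound 2 `Cc1nc(-c2ccc(F)cc2)oc1-c1csc(Cc2cccc(Cl)c2)n1` gives > 250 ug/mL in this assay, also a limit. For the measured compounds named here, the one measured step, a step that the two limits leave unreadable from compound 1 to compound 2, sits between two limits and cannot be sized. Compound 4 `Cc1nc(-c2ccccc2)oc1-c1csc(Cc2ccc(Cl)cc2)n1` differs from compound 3 by 4-chlorobenzyl in place of phenyl on an aromatic carbon, bringing 4-chlorobenzyl in place of phenyl on an aromatic carbon. Going by the values given here, no measured step reads on this change, but the limit of > 250 ug/mL in this assay, at which 3 of the 3 values shown sit, shows every value resting at the limit. Compound 4 is therefore expected to give 300 ug/mL, with a range from 120 ug/mL to 700 ug/mL. The expected step that the limit leaves unreadable from compound 3 to compound 4 is estimated to stay within the scatter.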

Compound 4, concentration for 50% growth inhibition: > 250 ug/mL
Compound 4 gave a limit, no number (the forecaster's own chance of this, stated with the estimate: 85%); the middle value does not contradict the limit.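

Compound 3 and compound 4 both rest at a limit, so no step can be read between them: the limit of > 250 ug/mL in this assay, at which 4 of the 4 values shown sit. The compounds shown leave open whether any change on the shared core alters growth inhibition.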